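Compound 3: taking off the side chain

The source may hold more compounds than are shown below. What is called first, only, known or untested is meant among the compounds shown, and "the series" means these compounds.

In a functional assay on K562 cells (Homo sapiens) for antiproliferative activity, read by MTT assay, with a stated time of 48 h (a higher number here means a weaker inhibitor, a lower number a stronger inhibitor), compound 3 `CN1CCN(CCCn2nc(C3=C(c4cn(C)c5ccccc45)C(=O)NC3=O)c3cccnc32)CC1` gives 46700 nM, the higher of two true numbers. Compound 2 `Cn1cc(C2=C(c3nn(CCCn4cccc4)c4ncccc34)C(=O)NC2=O)c2ccccc21` gives the other, 21600 nM, and a 2.2-fold higher number from compound 2 to compound 3 (0.33 log units; beyond the scatter) is modest. Compound 1 `Cn1cc(C2=C(c3nn(CCCn4cncn4)c4ncccc34)C(=O)NC2=O)c2ccccc21` reads > 100000 nM, which is a limit of the assay.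

Compound 4 `Cn1cc(C2=C(c3n[nH]c4ncccc34)C(=O)NC2=O)c2ccccc21` differs as follows: hydrogen in place of 3-(4-methylpiperazin-1-yl)propyl on an aromatic nitrogen. That is hydrogen in place of 3-(4-methylpiperazin-1-yl)propyl on an aromatic nitrogen. The nearest evidence is an at least 4.6-fold lower number from compound 1 to compound 2 (0.66 log units; beyond the scatter) and an at least 2.1-fold lower number from compound 1 to compound 3 (0.33 log units; beyond the scatter), along with the step above. All three only exchange the group at the end of the chain, and none removes the chain, so the guide is weak. The expected step is a 2.3-fold lower number from compound 3 to compound 4 (0.37 log units; beyond the scatter), modest and toward a lower number. For compound 4 the estimated value is 20000 nM, with an expected range of 4000 nM to 80000 nM.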

Compound 4, half-maximal inhibitory concentration: > 100000 nM
Compound 4: no number, only a limit (the forecaster's own chance of this, stated with the estimate: 15%); middle value at least 5.0-fold (0.69 log units) away from the limit.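

Compound 4 gives > 100000 nM, which is a limit of the assay and not a number. Replacing the whole chain with hydrogen on this aromatic nitrogen weakens the series: an at least 2.1-fold higher number from compound 3 to compound 4 (0.33 log units; beyond the scatter) and an at least 4.6-fold higher number from compound 2 to compound 4 (0.66 log units; beyond the scatter), so these chains matter, whereas earlier changes only exchanged the end group. The step involving compound 1 cannot be read, leaving 3-(1H-1,2,4-triazol-1-yl)propyl unseparated from hydrogen.

Still open, from the compounds shown here alone, is how a shorter chain, a longer chain, or a chain ending in a primary amine or a carboxylic acid would compare.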